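Replacing naphthalen-1-yl with 4-methylphenyl in compound 2

This account rests on a few compounds, and the source may have more. Where it says the series, first, only, none or still open, it means among the compounds named here.

Compound 1 `O=S(=O)(Oc1ccccc1)[C@H]1C[C@H]2O[C@@H]1C(c1ccc(O)cc1)=C2c1ccc(O)cc1`: > 100000 nM (a limit of the assay)
Compound 2 `O=C(O)CCCCCCC(=O)Nc1ccc(C2=C(c3ccc(O)cc3)C3CC(S(=O)(=O)Oc4cccc5ccccc45)C2O3)cc1`: 48600 nM
Compound 3 `COC(=O)CCCCCCC(=O)Nc1cccc(OS(=O)(=O)C2CC3OC2C(c2ccc(O)cc2)=C3c2ccc(O)cc2)c1`: 19300 nM

All three compounds were tested in a functional assay on DU-145 cells (Homo sapiens) for inhibition, read by MTT assay, with a stated time of 72 h; a higher number here means a weaker inhibitor, a lower number a stronger inhibitor. Compound 1 gives > 100000 nM, which is a limit of the assay and not a number. For the measured compounds named here, only two compounds have true numbers: compound 2 gives 48600 nM and compound 3 gives 19300 nM, so compound 2 stands the higher of the two. That gap lies beyond the usual scatter, so compound 2 is the weaker inhibitor of this pair.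

Compound 4 `Cc1ccc(OS(=O)(=O)C2CC3OC2C(c2ccc(NC(=O)CCCCCCC(=O)O)cc2)=C3c2ccc(O)cc2)cc1` differs from compound 2 in one place: 4-methylphenyl in place of naphthalen-1-yl on an oxygen whose other neighbour is the sulfonyl sulfur (4-methylphenyl in place of naphthalen-1-yl on an oxygen). Going by the values given here, no measured pair shows this swap on its own, so any expectation here is only a rough one. It leans on compound 2 at 48600 nM as the starting point and on compound 3 at 19300 nM as the nearest true number. The expected result is a 1.2-fold lower number from compound 2 to compound 4 (0.08 log units; within the scatter), a slightly lower number with no change beyond the scatter. For compound 4 the estimated value in this assay is 40000 nM, with an expected range of 15000 nM to 100000 nM.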

Compound 4, half-maximal inhibitory concentration: 80800 nM
Estimate against measurement, compound 4: 2.0-fold (0.31 log units) below, and the stated range covers the measured number.
By their numbers in this assay, from the lowest: compound 3; then compounds 2 and 4 (each within the scatter of the next). At a limit, above all of these: compound 1.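

In this assay, for the compounds shown here, a 1.7-fold higher number from compound 2 to compound 4 (0.22 log units; within the scatter), which is the first direct test of the group on the oxygen whose other neighbour is the sulfonyl sulfur. With the rest of compound 2 unchanged, this swap replaces two aromatic rings and 10 heavy atoms with one aromatic ring and 7 heavy atoms, yet the step stays within the usual scatter, so this reduction at this position gives no clear change in the read-out. This reading needs some caution because both compounds sit fairly close to the top of the range that the assay can report as a number: the limit of > 100000 nM in this assay, at which 1 of the 4 values shown sits.

The compounds shown leave open whether any group on this oxygen can shift the number beyond the scatter, for example a pyridin-3-yl ring, which carries a ring nitrogen, or a phenyl ring bearing an amine. Compound 3 differs from compound 2 and compound 4 in more than one place, so it cannot settle this question.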